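Working notes: methylsulfanyl to 5-carbamoylpyridin-2-yl replacement

The compounds below may be only part of what the source reports. "The series", "measured", "known", "first", "only" and "open" are said of these compounds alone.

Measured so far:
compound 1 `CS(=O)(=O)c1cnc(C(=O)CCc2ccc(-c3ccccc3)cc2)o1`, 1.2 nM
compound 2 `CSc1cnc(C(=O)CCc2ccc(-c3ccccc3)cc2)o1`, 3 nM

Going by the values given here, in an assay for inhibition of Fatty-acid amide hydrolase 1 (Rattus norvegicus) (on this read-out lower numbers stand for stronger inhibition and higher numbers for weaker inhibition), compound 2 stands at the higher of the two numbers, with compound 1 as its only neighbour. Among the compounds with values here, the single measured step in this assay, a 2.5-fold higher number from compound 1 to compound 2 (0.40 log units; beyond the scatter), is the whole of the local record.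

Compound 3 `NC(=O)c1ccc(-c2cnc(C(=O)CCc3ccc(-c4ccccc4)cc3)o2)nc1` has not yet been measured in this assay. Relative to compound 2 it carries the change (5-carbamoylpyridin-2-yl in place of methylsulfanyl on an aromatic carbon). Within the data shown here, this is a swap of a small group for a much larger aromatic one, and no measured step touches a change of that kind; the only step, a 2.5-fold higher number from compound 1 to compound 2 (0.40 log units; beyond the scatter), compares two small sulfur-bearing groups and says nothing direct about an appended six-membered ring. The direction for compound 3 is therefore open. As a working expectation, compound 3 is estimated near compound 2, at 2 nM with a range of 0.3 nM to 15 nM. The expected step is a 1.5-fold lower number from compound 2 to compound 3 (0.18 log units; within the scatter), and a result anywhere within the scatter of compound 2 would not be surprising.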

Compound 3, inhibition constant: 1.3 nM
The estimate for compound 3 lay 1.5-fold (0.19 log units) above the measured number, and the stated range covers the measured number.
By their numbers in this assay, from the lowest: compounds 1 and 3 (each within the scatter of the next); then compound 2.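

Read in this assay, the aromatic carbon next to the ring oxygen takes a far larger group than the earlier sulfur-bearing substituents, with one six-membered aromatic ring and 9 heavy atoms, and 5-carbamoylpyridin-2-yl in place of methylsulfanyl gives a modest gain (a 2.3-fold lower number from compound 2 to compound 3 (0.36 log units; beyond the scatter)). Set against methylsulfonyl, the same group shows no separation (a 1.1-fold higher number from compound 1 to compound 3 (0.03 log units; within the scatter)), so a small substituent and a large one sit level on this read-out while methylsulfanyl stands apart from both. Nothing at hand explains why these groups compare as they do.

On these data alone, it remains open whether the gain over compound 2 depends on the carbamoyl group or comes with the pyridine ring alone, a question that an unsubstituted pyridin-2-yl, a phenyl, or a carboxylic acid or nitrile in place of the carbamoyl group would help to separate. Also open, as far as these compounds go, is how much further this carbon can be built out, for instance with a morpholine-bearing ring or a longer chain on the amide nitrogen, before the number rises.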